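Hydroxy to propyl on the imine side chain

The source may report more compounds than this note shows. Statements on the series, on what has been measured and on what is new or still open speak of the compounds shown alone.

Measured compounds in an assay on isolated protein for inhibition of myosin-2 (Bos taurus), read by spectrophotometry, with a stated time of 24 min; on this read-out lower numbers stand for stronger inhibition and higher numbers for weaker inhibition:
- compound 1, `C/C(=N\CCO)c1c(O)c2ccccc2[nH]c1=O`: >= 100000 nM
- compound 2, `C/C(=N\C(C)C)c1c(O)c2ccccc2oc1=O`: >= 100000 nM
- compound 3, `CC/C(=N\Cc1ccccc1)c1c(O)c2ccccc2oc1=O`: >= 100000 nM

In this assay compound 1 gives >= 100000 nM, which is a limit of the assay and not a number. The same holds for compound 2, whose value of >= 100000 nM is also a limit. Compound 3 likewise returns >= 100000 nM, a limit. Going by the values given here, compound 1 therefore stands with the other two at the limit of >= 100000 nM in this assay, at which 3 of the 3 values shown sit, and nothing in the measured set separates the three from one another; no step between measured compounds can be read, so no direction of change has been seen anywhere.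

Compound 4, `CCCCC/N=C(\C)c1c(O)c2ccccc2[nH]c1=O`, is not yet measured in this assay. It differs from compound 1 by propyl in place of hydroxy on a saturated chain carbon, two bonds along the chain from a double-bonded nitrogen. No shown step connects a change of this kind to a change in the read-out, so there is no measured basis for expecting movement in either direction; the expectation is that the step from compound 1 to compound 4 stays within the usual scatter, a number no higher from compound 1 to compound 4 (the limit leaves the size open) being the estimated size. On that basis compound 4 is expected to sit at about 100000 nM, with a range from 30000 nM to 300000 nM, and a sizeable chance that this assay again reports only a limit.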

Compound 4, half-maximal inhibitory concentration: >= 100000 nM
Compound 4 was reported as a limit; the forecaster's own chance of this, stated with the estimate: 70%; the middle value lies on the limit itself.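

In this assay compound 4 gives >= 100000 nM, a limit of the assay and not a number. Going by these compounds alone, compound 1 is also reported only as a limit, so no step from compound 1 to compound 4 can be read. The compounds shown leave open whether any change to the imine side chain or the shared core moves the read-out, with every value held at one limit: the limit of >= 100000 nM in this assay, at which 4 of the 4 values shown sit.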